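Expanding the Amide Substituent on a Shared Core

The source may hold more compounds than are shown below. What is called first, only, known or untested is meant among the compounds shown, and "the series" means these compounds.

Of the compounds shown here, two built on the same core have been measured in an assay on isolated protein for displacement of a labelled ligand from Adrenergic receptor alpha-1 (Rattus norvegicus); a lower number here means a stronger inhibitor, a higher number a weaker inhibitor. Compound 1 `CCCCNC(=O)C1CCN(c2nc(N)c3cc(OC)c(OC)cc3n2)CC1` gives 0.67 nM in this assay. Compound 2 `CCN(CC)C(=O)C1CCN(c2nc(N)c3cc(OC)c(OC)cc3n2)CC1` gives 1.11 nM in this assay. Of the two numbers, compound 2 carries the higher one, its nearest neighbour being compound 1, yet the gap between them, a 1.7-fold higher number from compound 1 to compound 2 (0.22 log units; within the scatter), lies within the scatter and so signals no real difference.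

Compound 3 `COc1cc2nc(N3CCC(C(=O)NCCOc4ccccc4)CC3)nc(N)c2cc1OC` has not yet been measured. It differs from compound 2 by (2-phenoxyethyl)amino in place of diethylamino on a carbonyl carbon. Among the compounds with values here, the only measured step touching this position is a 1.7-fold higher number from compound 1 to compound 2 (0.22 log units; within the scatter), which stayed within the scatter. Within the data shown here, no measured compound carries an entering group of this kind, so the expectation rests on that single, flat step alone. Compound 3 is therefore expected to show no shift beyond the scatter, an estimated 1.4-fold lower number from compound 2 to compound 3 (0.14 log units; within the scatter). For compound 3 the estimate in this assay is 0.8 nM, ranging from 0.3 nM to 2.5 nM.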

Compound 3, inhibition constant: 0.42 nM
Estimate against measurement, compound 3: 1.9-fold (0.28 log units) above; the range from low to high includes it.
By their numbers in this assay, from the lowest: compounds 3, 1 and 2 (each within the scatter of the next, the first and the last beyond it).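

The substituent on the carbonyl carbon is shown by this assay to be able to move the number beyond the scatter, which the earlier pair did not show. Replacing diethylamino with (2-phenoxyethyl)amino gives a modest gain (a 2.6-fold lower number from compound 2 to compound 3 (0.42 log units; beyond the scatter)), so a larger substituent with a six-membered aromatic ring is tolerated here with no loss of binding. The same comparison made against the butyl amide gives no separation (a 1.6-fold lower number from compound 1 to compound 3 (0.20 log units; within the scatter)), so phenoxy in place of ethyl on the chain makes no difference that can be read, and the gain appears only against diethylamino.

As far as these compounds go, whether a longer chain bearing the phenoxy group, or a terminal amine or carboxylic acid on the chain, would keep these numbers remains open. Nothing available explains the step from diethylamino to (2-phenoxyethyl)amino.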